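Moving the fluorine on the triazole aryl group

This account rests on a few compounds, and the source may have more. Where it says the series, first, only, none or still open, it means among the compounds named here.

Compound 1 `Cc1cccc(-n2cc(-c3ccccc3NS(=O)(=O)c3c[nH]c(=O)[nH]c3=O)nn2)c1`: 3620 nM
Compound 2 `O=c1[nH]cc(S(=O)(=O)Nc2ccccc2-c2cn(-c3cccc(F)c3)nn2)c(=O)[nH]1`: > 20000 nM

In a functional assay on HepG2 cells (Homo sapiens) for antiproliferative activity, read by MTT assay, with a stated time of 24 h (on this read-out lower numbers stand for stronger inhibition and higher numbers for weaker inhibition), compound 1 gives 3620 nM. Compound 2 sits at a limit of the assay, > 20000 nM; the step of an at least 5.5-fold higher number from compound 1 to compound 2 (0.74 log units; beyond the scatter) rests on that limit (the limit of > 20000 nM in this assay, at which 1 of the 2 values shown sits). Compound 3 `O=c1[nH]cc(S(=O)(=O)Nc2ccccc2-c2cn(-c3ccc(F)cc3)nn2)c(=O)[nH]1` differs from compound 2 by 4-fluorophenyl in place of 3-fluorophenyl on an aromatic nitrogen. Among the measured compounds shown here, no measured step changes the position of a substituent, so the only guide is that compound 2 stands at the limit. Compound 3 is therefore expected to stay near that limit, with the step of a number no higher from compound 2 to compound 3 (the limit leaves the size open) estimated as within the scatter, and its value expected around 20000 nM (5000 nM to 60000 nM).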

Compound 3, half-maximal inhibitory concentration: > 20000 nM
Compound 3 gave a limit, no number; the forecaster's own chance of this, stated with the estimate: 60%; the middle value sits exactly at the limit.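

Compound 3 also stands at a limit of this assay, > 20000 nM, and not at a number. With 4-fluorophenyl on the aromatic nitrogen, the change from 3-methylphenyl gives an at least 5.5-fold higher number from compound 1 to compound 3 (0.74 log units; beyond the scatter), so among these compounds the loss is not confined to one fluorine position. The step between the two fluorophenyl compounds cannot be read, and how far apart they lie stays unknown: the limit of > 20000 nM in this assay, at which 2 of the 3 values shown sit.

Going by these compounds, whether an amine or a carboxylic acid in place of the fluorine would return a readable value stays open. So does whether 4-methylphenyl would keep the activity of 3-methylphenyl.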